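Swapping the Amine Tail of Compound 2

The source may hold more compounds than are shown below. What is called first, only, known or untested is meant among the compounds shown, and "the series" means these compounds.

Compound 2 `CC(C)=CCc1cc(C(=O)Nc2cc3ccc(OCCCN4CCCC4)c(C)c3oc2=O)ccc1O` gives 990 nM in a functional assay on MCF7 cells (Homo sapiens) for antiproliferative activity; on this read-out higher numbers stand for weaker inhibition and lower numbers for stronger inhibition. Compound 1 `CC(=O)Oc1ccc(C(=O)Nc2cc3ccc(OCC4CCCN(C)C4)c(C)c3oc2=O)cc1CC=C(C)C` gives 1650 nM in this assay, and the two numbers lie within the usual scatter of each other. Compound 3 `CCCN(CCC)CCCOc1ccc2cc(NC(=O)c3ccc(O)c(CC=C(C)C)c3)c(=O)oc2c1C` reaches only the limit > 50000 nM in this assay. Compound 4 `CC(C)=CCc1cc(C(=O)Nc2cc3ccc(OCCCNC(C)(C)C)c(C)c3oc2=O)ccc1O` differs from compound 2 by (tert-butyl)amino in place of pyrrolidin-1-yl on a saturated chain carbon, three bonds along the chain from an oxygen on an aromatic ring. Within the data shown here, one measured step bears on this: because an at least 50-fold higher number from compound 2 to compound 3 (1.70 log units; beyond the scatter) also replaced the ring amine with an open-chain amine, resting on (the limit of > 50000 nM in this assay, at which 1 of the 3 values shown sits), a weakening step is expected here as well, though a smaller one seems plausible since the new group keeps a hydrogen-bond donor. Compound 4 is therefore estimated at 8000 nM, between 2000 nM and 50000 nM, which would mean an expected 8.1-fold higher number from compound 2 to compound 4 (0.91 log units; beyond the scatter).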

Compound 4, half-maximal inhibitory concentration: 950 nM
Compound 4: middle estimate off by 8.4-fold (0.93 log units), on the high side, and the stated range ends above it.
By their numbers in this assay, from the lowest: compounds 4, 2 and 1 (each within the scatter of the next). At a limit, above all of these: compound 3.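

An open-chain amine is not in itself a problem at this position: in this assay, (tert-butyl)amino in place of pyrrolidin-1-yl gives a 1.0-fold lower number from compound 2 to compound 4 (0.02 log units; within the scatter), so the ring can be given up with no change beyond the scatter. Compound 3 stands at a limit of the assay, > 50000 nM, not at a number. Between the two open-chain amines, (tert-butyl)amino in place of dipropylamino gives an at least 52-fold lower number from compound 3 to compound 4 (1.72 log units; beyond the scatter), so the loss goes with dipropylamino rather than with opening the ring.

Still open, from the compounds shown here alone, is how a diethylamino or piperidin-1-yl group would fare on the same chain. Also open, going by these compounds, is whether the hydrogen on the nitrogen of (tert-butyl)amino is what separates compound 4 from compound 3.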